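Amide in place of a urea link on a shared core

The source may hold more compounds than are shown below. What is called first, only, known or untested is meant among the compounds shown, and "the series" means these compounds.

Measured so far:
compound 1, `COc1cc(-c2nn(-c3ccc(NC(=O)Nc4ccc(Cl)c(Cl)c4)cc3)cc2-c2ccncc2)ccc1Cl`, 1980 nM in a functional assay on LOX IMVI cells (Homo sapiens) for antiproliferative activity, read by sulforhodamine B assay, with a stated time of 48 h; a lower number here means a stronger inhibitor, a higher number a weaker inhibitor
compound 2, `COc1cc(-c2nn(-c3ccc(NC(=O)Nc4ccc(Cl)c(C(F)(F)F)c4)cc3)cc2-c2ccncc2)ccc1Cl`, 1430 nM

Of the compounds shown here, two have been tested. Compound 2 gives the lowest of the two numbers, but its step from compound 1, a 1.4-fold lower number from compound 1 to compound 2 (0.14 log units; within the scatter), is within the scatter, so the two cannot be ranked against each other.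

Compound 3, `COc1cc(-c2nn(-c3ccc(NC(=O)c4ccc(Cl)c(Cl)c4)cc3)cc2-c2ccncc2)ccc1Cl`, has not yet been measured. It differs from compound 2 in one place: 3,4-dichlorophenyl in place of (4-chloro-3-(trifluoromethyl)phenyl)amino on a carbonyl carbon. This removes the nitrogen that carried a hydrogen-bond donor and shortens the link between the two aromatic rings.

Among the compounds with values here, no measured step touches that link; the only measured step, from compound 1 to compound 2, exchanges one substituent on the outer ring and is within the scatter. Within the data shown here, the expectation for compound 3 therefore rests on no direct precedent and is wide. Compound 3 is estimated at 2500 nM, within 800 nM to 8000 nM, a step of a 1.7-fold higher number from compound 2 to compound 3 (0.24 log units; within the scatter) that is expected to be small against the scatter.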

Compound 3, half-maximal inhibitory concentration: 2760 nM
Compound 3: the middle estimate sits 1.1-fold (0.04 log units) below what was measured; the measured number falls inside the stated range.
By their numbers in this assay, from the lowest: compounds 2, 1 and 3 (each within the scatter of the next).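

Within the data shown here, compound 1 and compound 3 share the same 3,4-dichlorophenyl group, so they isolate the change from urea to amide link: in this assay there is a 1.4-fold higher number from compound 1 to compound 3 (0.14 log units; within the scatter) and this is the first measured step that touches the link. The other new step, a 1.9-fold higher number from compound 2 to compound 3 (0.29 log units; within the scatter) with the ring substituents changing as well, also stays within the scatter. These two steps show that, at this level of activity, removing the urea nitrogen with its hydrogen-bond donor gives no readable difference, and nothing measured here bears on why.

The compounds shown leave open how a sulfonamide link or a longer chain carrying an extra methylene would compare. They also leave open what a methoxy group or an amine would do on the outer ring of the amide series.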